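Fixing both stereocentres: from a mixture to one isomer

The source may report more compounds than this note shows. Statements on the series, on what has been measured and on what is new or still open speak of the compounds shown alone.

Compound 2 `C=CCc1cc(OC)c(OC(C)C(OCC)c2ccc(O)c(OC)c2)c(OC)c1` is drawn without configuration at either of its two stereocentres, so it stands for a mixture of isomers. Among the compounds with values here, in an assay on HEK293 cells for agonist activity at transient receptor potential cation channel subfamily M member 8 (Homo sapiens), read by fluorescence and calcium flux, with a stated time of 5 min (a lower number here means that less compound is needed, a higher number that more compound is needed for the effect), compound 2 gives 332 nM, the lowest of the two numbers measured so far. Compound 1 `C=CCc1cc(OC)c(O[C@H](C)[C@@H](OCC)c2ccc(O)c(OC)c2)c(OC)c1` is a single isomer with both centres defined, and in this assay compound 1 gives 1150 nM. The step of a 3.5-fold lower number from compound 1 to compound 2 (0.54 log units; beyond the scatter) may rest on the fact that one of compounds 1 and 2 is drawn with a defined configuration and the other without, at the place where they differ: a mixture that needs less compound than one pure isomer must contain another isomer that needs less still. Compound 3 `C=CCc1cc(OC)c(O[C@@H](C)[C@@H](OCC)c2ccc(O)c(OC)c2)c(OC)c1` differs from compound 2 as follows: the two compounds have the same atoms and bonds; at least one stereo element is drawn with a configuration in one of them and without one in the other: 2 of 2 stereo elements differ; a stereocentre at a saturated chain carbon is drawn without a configuration in compound 2 and S in compound 3; a stereocentre at a saturated chain carbon is drawn without a configuration in compound 2 and S in compound 3. Compound 3 could be that better isomer, or a different, weaker one, so a step of the expected size a 1.1-fold lower number from compound 2 to compound 3 (0.04 log units; within the scatter) in this assay is uncertain in direction. For compound 3 the expected number in this assay is 300 nM, with a range from 70 nM to 1500 nM.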

Compound 3, half-maximal effective concentration: 87 nM
The estimate for compound 3 lay 3.4-fold (0.54 log units) above the measured number, within the range that was stated.
By their numbers in this assay, from the lowest: compound 3; then compound 2; then compound 1.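

Compound 3 shows that the mixture's number hid a better single isomer: in this assay there is a 3.8-fold lower number from compound 2 to compound 3 (0.58 log units; beyond the scatter), and this step can be tied to how the stereocentres are drawn: the fact that one of compounds 2 and 3 is drawn with a defined configuration and the other without, at the place where they differ. Inverting one saturated chain carbon from R to S, with the other stereocentre drawn S in compound 3, gives a 13-fold lower number from compound 1 to compound 3 (1.12 log units; beyond the scatter), and nothing else separates the two structures: the fact that compounds 1 and 3 differ only in the configuration as drawn. Configuration at this one carbon therefore has a large effect on the number in this pair, something the comparison with the mixture could not isolate.

From the compounds shown here alone, what the isomers with the other stereocentre drawn R would give stays open, so the make-up of the mixture's number cannot be worked out. Also open, going by these compounds, is whether the preference for S would hold with an amine or a carboxylic acid added to the shared core.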